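The compounds below may be only part of what the source reports. "The series", "measured", "known", "first", "only" and "open" are said of these compounds alone.

Compound 1, `O=S(=O)(NCCCNCc1ccccc1Cl)c1cc(C(F)(F)F)cc(C(F)(F)F)c1`, is the weaker of the two measured compounds: in a functional assay on Capan-2 cells (Homo sapiens) for inhibition, read by MTT assay, with a stated time of 72 h (on this read-out higher numbers stand for weaker inhibition of growth and lower numbers for stronger inhibition of growth), compound 1 gives 13000 nM. Compound 2, `O=S(=O)(NCCCNCc1ccc(Cl)c(Cl)c1)c1cc(C(F)(F)F)cc(C(F)(F)F)c1`, carries the same core and the same chain, and in this assay compound 2 gives 1800 nM. Among the compounds with values here, the single measured step, a 7.2-fold lower number from compound 1 to compound 2 (0.86 log units; beyond the scatter), therefore places compound 2 at the lowest number of the two, with compound 1 as its only neighbour. Compound 3, `O=S(=O)(NCCCNCc1ccc(Cl)c(C(F)(F)F)c1)c1cc(C(F)(F)F)cc(C(F)(F)F)c1`, is the next compound along this line; the change from compound 2 is trifluoromethyl in place of chloro on an aromatic carbon. Within the data shown here, only one measured step bears on this change, and it bears only indirectly, since it moved chlorine from one position to another on the same ring rather than exchanging a chloro for a trifluoromethyl. Among the measured compounds shown here, with that step as the sole guide, the exchange is expected to bring a step of about a 1.2-fold lower number from compound 2 to compound 3 (0.08 log units; within the scatter), which is within the scatter, so neither a clear gain nor a clear loss is expected. Compound 3 is accordingly estimated at 1500 nM, with a range from 500 nM to 5000 nM.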

Compound 3, concentration for 50% growth inhibition: 9100 nM
Beside the measured number, compound 3's estimate is 6.1-fold (0.78 log units) below it, outside the stated range (above it).
By their numbers in this assay, from the lowest: compound 2; then compounds 3 and 1 (each within the scatter of the next).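

The exchange of chloro for trifluoromethyl on this aromatic carbon, ortho to a chloro group and meta to a large group, is not neutral in this assay: it brings a 5.1-fold higher number from compound 2 to compound 3 (0.70 log units; beyond the scatter), so this carbon responds to the group it carries, which the earlier move of chlorine around the ring could not show. The 4-chloro-3-(trifluoromethyl)phenyl group also stands level with the 2-chlorophenyl group, with a 1.4-fold lower number from compound 1 to compound 3 (0.15 log units; within the scatter), so among these three compounds only the 3,4-dichlorophenyl group of compound 2 stands apart from the others on this read-out. Nothing given here accounts for the size of this step.

The compounds shown leave open whether the number of compound 2 depends on chlorine itself at this carbon or would also hold with a fluoro, methyl or methoxy group there. They also leave open how the 3,4-dichlorophenyl group behaves on a shorter or longer chain, or with an amide in place of the amine nitrogen.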